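A Ring Stereocentre Inverted Under a Half-Life Limit

The compounds below may be only part of what the source reports. "The series", "measured", "known", "first", "only" and "open" are said of these compounds alone.

Compound 1 (`O=C(O)[C@@H](CO)NC(=O)[C@H]1C[C@H](O)CN1`): > 12 h (a limit)
Compound 2 (`O=C(N[C@H](CO)C(=O)O)[C@@H]1C[C@H](O)CN1`): > 12 h (a limit)
Compound 3 (`O=C(O)[C@H](CO)NC(=O)[C@@H]1C[C@H](O)CN1`): > 12 h (a limit)

In an ADME assay on Caco-2 cells (Homo sapiens) for metabolic stability, read by HPLC, with a stated time of 12 h (a lower number here means that the compound disappears faster, a higher number that the compound lasts longer), compound 3 gives > 12 h as a limit and not a number. The two further values are limits too, so the record holds the limit of > 12 h in this assay, at which 3 of the 3 values shown sit, and no exact half-life.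

Compound 4 (`O=C(O)[C@H](CO)NC(=O)[C@@H]1C[C@@H](O)CN1`) is the next stereoisomer to be measured, and its change from compound 3 is this: the two compounds have the same atoms and bonds and differ only in configuration as drawn: 1 of 3 stereo elements differ; a stereocentre at a saturated ring carbon is drawn S in compound 3 and R in compound 4 and nothing leaves or enters. Among the measured compounds shown here, the closest precedent is a step that the two limits leave unreadable from compound 1 to compound 2 and it, too, concerns a stereocentre at a saturated ring carbon. Two other changes of configuration also give no size, namely a step that the two limits leave unreadable from compound 2 to compound 3 and a step that the two limits leave unreadable from compound 1 to compound 3 in the same series. None of these steps shows any loss of stability, although none can be sized either.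

No step beyond the scatter is therefore expected, and the estimate is a step that the limit leaves unreadable from compound 3 to compound 4 with no direction supported by the measurements. In this assay compound 4 is estimated at 16 h with an expected range from 12 h to 30 h and it will most likely be reported only as a limit.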

Compound 4, half-life: > 12 h
Compound 4: a limit, no number; the forecaster's own chance of this, stated with the estimate: 85%; the middle value lies beyond the limit too.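

In this assay compound 4 gives > 12 h, which is a limit and not a number, so none of the steps to compound 4 from compound 1, compound 2 or compound 3 can be read. The compounds shown leave open how long any of these four stereoisomers actually lasts in this assay, and whether configuration changes the half-life at all.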